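The source may hold more compounds than are shown below. What is called first, only, known or untested is meant among the compounds shown, and "the series" means these compounds.

The measured compounds are:
compound 1, `COc1c(/C=C2/C(=O)Nc3ccc(Cl)cc32)c2ccccc2n1-c1ccccc1`, which in a functional assay on cells (Cancer cell lines, Homo sapiens) for cytotoxicity, with a stated time of 48 h (a higher number here means a weaker inhibitor of growth, a lower number a stronger inhibitor of growth), gives 24000 nM;
compound 2, `COc1cc2c(/C=C3/C(=O)Nc4ccc(O)cc43)c(Cl)n(Cc3cc(OC)c(OC)c(OC)c3)c2cc1C`, which in this assay gives 50100 nM;
compound 3, `COc1cc2c(cc1C)NC(=O)/C2=C/c1c(Cl)n(Cc2cc(OC)c(OC)c(OC)c2)c2cc(C)c(OC)cc12`, which in this assay gives 87100 nM.

Compound 1 has the lowest of the three numbers in this assay and is the strongest growth inhibitor of the set: compound 2 lies beyond the usual scatter above it, and compound 3 further still. Compound 2 and compound 3 differ from compound 1 in many places at once, so no single structural change can be read from them.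

Compound 4, `COc1c(/C=C2/C(=O)Nc3ccccc32)c2ccccc2n1-c1ccccc1`, has not yet been measured in this assay. It differs from compound 1 in one place: hydrogen in place of chloro on an aromatic carbon. Among the compounds with values here, no pair of measured compounds differs by this change alone, so there is no measured step to lean on. The number for compound 4 is expected to move little from that of compound 1, perhaps slightly upward, and most likely within the scatter. The expected step is a 1.5-fold higher number from compound 1 to compound 4 (0.16 log units; within the scatter). Compound 4 is therefore estimated to give 35000 nM in this assay, with a plausible range from 12000 nM to 100000 nM.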

Compound 4, concentration for total growth inhibition: 3470 nM
Compound 4: the middle estimate sits 10-fold (1.00 log units) above what was measured; measured number outside the range, below it.
By their numbers in this assay, from the lowest: compound 4; then compound 1; then compounds 2 and 3 (each within the scatter of the next).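

In this assay, replacing the chloro with hydrogen gives a 6.9-fold lower number from compound 1 to compound 4 (0.84 log units; beyond the scatter) and so shows that, on this aromatic carbon of the shared core, the chloro is not needed for growth inhibition; the compound without it is the stronger inhibitor of the pair. Within the data shown here, this is the first comparison in the set that changes one place only, so this position can now be judged apart from the many differences that separate compound 2 and compound 3 from compound 1. Nothing measured here accounts for the size or the direction of this step.

The compounds shown leave open whether any group on this carbon raises the number or whether the result is particular to chloro, and a fluoro, a bromo or a nitrile in the same place would help to separate those two readings. They also leave open whether the same change would give a similar step on other cores, since this single pair is the only place where it can be read.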